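The compounds below may be only part of what the source reports. "The series", "measured", "known", "first", "only" and "open" are said of these compounds alone.

Compound 2 `CC(C)N(c1ccnc(Nc2ccc(C#N)cc2)n1)c1c(F)cc(-c2ccc(C#N)cc2)cc1F` and compound 1 `CCCCN(c1ccnc(Nc2ccc(C#N)cc2)n1)c1c(F)cc(-c2ccc(C#N)cc2)cc1F` share the same core and differ only in the chain carried on a nitrogen on an aromatic ring. Going by the values given here, in an ADME assay on MT4 cells (Homo sapiens) for cytotoxicity, read by MTT assay, with a stated time of 5 days (on this read-out higher numbers stand for lower toxicity in this test and lower numbers for higher toxicity in this test), compound 2 gives 172000 nM, which is the lowest of the two numbers measured so far; in this assay compound 1 gives 211000 nM. Among the compounds with values here, the only measured step, a 1.2-fold lower number from compound 1 to compound 2 (0.09 log units; within the scatter), swaps one short chain for another on that nitrogen and stays within the scatter.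

Compound 3 `CC(C)CN(c1ccnc(Nc2ccc(C#N)cc2)n1)c1c(F)cc(-c2ccc(C#N)cc2)cc1F` has not yet been measured. It differs from compound 2 as follows: isobutyl in place of isopropyl on a nitrogen on an aromatic ring. Within the data shown here, this is again a swap of one short chain for another at the same place, so the one step that bears on it, from compound 1 to compound 2, suggests no movement beyond the scatter. For compound 3 the expected step is therefore a 1.1-fold higher number from compound 2 to compound 3 (0.03 log units; within the scatter), and the estimate is 185000 nM, with a range from 95000 nM to 360000 nM.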

Compound 3, half-maximal cytotoxic concentration: 241000 nM
For compound 3 the middle estimate is 1.3-fold (0.11 log units) below the measured one; measured number inside the range.
By their numbers in this assay, from the lowest: compounds 2, 1 and 3 (each within the scatter of the next).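

Isobutyl in place of isopropyl on the nitrogen gives a 1.4-fold higher number from compound 2 to compound 3 (0.15 log units; within the scatter) in this assay and so adds a second chain swap at this place that stays within the scatter. The straight butyl and the branched isobutyl chains are just as close, with a 1.1-fold higher number from compound 1 to compound 3 (0.06 log units; within the scatter) as their step, which the earlier pair could not show. Among these three chains, neither swapping isopropyl for isobutyl nor branching the butyl chain separates the compounds in this test, and no measurement offered here explains this.

As far as these compounds go, what stays open is whether a group of a different kind on this nitrogen, such as an amine or a carboxylic acid, would move the number beyond the scatter. From the compounds shown here alone, a much longer chain remains equally open.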